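One Carbon Shorter: What to Expect for Compound 3

A few compounds are considered here, and "the series" means these few. Any claim that something is new, unique, unknown or untested is made for them only; others in the source may bear on it.

Measured so far:
Compound 1, `O=C(CCCCCCc1cn(-c2ccccc2-c2ccccc2)nn1)NCc1cccnc1`: 47%
Compound 2, `O=C(CCCCCCCCc1cn(-c2cnc3ccccc3c2)nn1)NCc1cccnc1`: 29%

Both compounds were tested in a functional assay on SH-SY5Y cells (Homo sapiens) for cytotoxicity, read by MTT assay, with a stated time of 48 h, tested at 10 uM; a higher number here means a weaker effect of the compound at the concentration tested, a lower number a stronger effect. In this assay compound 1 gives 47%, the highest of the two numbers. Compound 2 gives 29%, a number lower by an amount beyond the usual scatter. Compound 1 and compound 2 differ in more than one place, so no single structural change can be tied to that gap.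

Compound 3, `O=C(CCCCCc1cn(-c2ccccc2-c2ccccc2)nn1)NCc1cccnc1`, has not been measured. It differs from compound 1 in one place: ((pyridin-3-yl)methyl)carbamoyl in place of (((pyridin-3-yl)methyl)carbamoyl)methyl on a saturated chain carbon, five bonds along the chain from an aromatic carbon. The change shortens the saturated chain and leaves the rest of the molecule untouched. For the measured compounds named here, nothing among the measured compounds isolates the effect of chain length alone, so a step in this assay of no more than the usual scatter is expected, in either direction. The expected step of a number 3 percentage points higher from compound 1 to compound 3 (within the scatter) is small. Compound 3 is estimated to give 50%, within a range from 32% to 68%.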

Compound 3, a percentage reported as activity, at one concentration (the size of the read-out at that concentration, not a potency): 12.5%
For compound 3 the middle estimate is 37.5 percentage points above the measured one; the whole stated range lies above it.
By their numbers in this assay, from the lowest: compound 3; then compound 2; then compound 1.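

In this assay, shortening the saturated chain and changing nothing else gives a large step, a number 34.5 percentage points lower from compound 1 to compound 3 (beyond the scatter), and the lower number means a stronger effect at the concentration tested. For the compounds shown here, this is the first view of chain length on its own, since compound 1 and compound 2 differ in more than one place and their gap could not be tied to any single change. The place on a saturated chain carbon, five bonds along the chain from an aromatic carbon, is therefore sensitive to this change, although nothing at hand explains the size of the step.

Going by these compounds, a single pair gives a step and not a trend, so the direction of any further change in chain length remains open. A still shorter chain, or an ether oxygen within the chain, on the core of compound 1 would show whether the effect continues or depends on the chain's carbons.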